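A few compounds are considered here, and "the series" means these few. Any claim that something is new, unique, unknown or untested is made for them only; others in the source may bear on it.

Of the compounds shown here, three from this series have been tested in an ADME assay on HEp-2 cells (Homo sapiens) for cytotoxicity, read by MTT assay, with a stated time of 3 days; on this read-out lower numbers stand for higher toxicity in this test and higher numbers for lower toxicity in this test. Compound 1, `CC[C@H](CCn1cncn1)c1ccc(Cl)cc1`, gives 50.6 ug/mL; compound 2, `CCC[C@H](CCn1cncn1)c1ccccc1`, gives 58.4 ug/mL; compound 3, `CCCC[C@H](CCn1cncn1)c1ccccc1`, gives 50.2 ug/mL. On these numbers compound 3 stands at the low end, but its nearest neighbour compound 1 lies within the scatter of it and so does compound 2, so the three values cannot be told apart.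

Compound 4, `CCCC[C@H](CCn1cncn1)c1ccc(Cl)cc1`, has not yet been measured. It differs from compound 3 by chloro in place of hydrogen on an aromatic carbon. Among the compounds with values here, the one measured step, a 1.2-fold lower number from compound 2 to compound 3 (0.07 log units; within the scatter), concerns a chain and does not bear on a chloro group, so no measured step speaks directly to this change. What the data do show is that compound 1, which carries the chloro group, and compound 3, which does not, give values within the scatter of each other, although they also differ in chain length. On that basis compound 4 is expected to move by about a 1.0-fold lower number from compound 3 to compound 4 (0.00 log units; within the scatter), that is, by no more than the scatter in this assay. Compound 4 is therefore estimated at 50 ug/mL, with a range from 30 ug/mL to 85 ug/mL.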

Compound 4, half-maximal cytotoxic concentration: 20.2 ug/mL
Compound 4: the middle estimate sits 2.5-fold (0.39 log units) above what was measured, outside the stated range (below it).
By their numbers in this assay, from the lowest: compound 4; then compounds 3, 1 and 2 (each within the scatter of the next).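

In this assay, chloro in place of hydrogen on an aromatic carbon, para to a large group, gives a 2.5-fold lower number from compound 3 to compound 4 (0.40 log units; beyond the scatter), so this position does respond to the change when the rest of compound 3 is kept. Ethyl in place of hydrogen on a saturated chain carbon, three bonds along the chain from an aromatic carbon, gives a 2.5-fold lower number from compound 1 to compound 4 (0.40 log units; beyond the scatter), which shows that chain length matters with chloro present, whereas the one earlier chain step, taken without chloro, was a 1.2-fold lower number from compound 2 to compound 3 (0.07 log units; within the scatter). Nothing available explains why the number falls with either change.

The compounds shown leave open whether fluoro, methoxy or a carboxylic acid at the same place would lower the number as chloro does. They also leave open whether a longer chain would lower it further with chloro present.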